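The source may hold more compounds than are shown below. What is called first, only, known or untested is meant among the compounds shown, and "the series" means these compounds.

Measured so far in an ADME assay on Huh7.5.1 cells (Homo sapiens) for cytotoxicity, read by ATP content, with a stated time of 48 h; a lower number here means that less compound is tolerated, a higher number that more compound is tolerated:
compound 1 `Cc1ccc(C)c(-c2nc(CN3CCC(C(=O)NCCCN4C[C@H](C)C[C@H](C)C4)CC3)c(C)o2)c1`: 4070 nM
compound 2 `Cc1oc(-c2c(Cl)cccc2Cl)nc1CN1CCC(C(=O)NCCCN2C[C@H](C)C[C@H](C)C2)CC1`: 13200 nM
compound 3 `COc1cccc(Br)c1-c1nc(CN2CCC(C(=O)NCCCN3C[C@H](C)C[C@H](C)C3)CC2)c(C)o1`: 14900 nM

Compound 3 gives the highest number of the three in this assay; compound 2 sits within the scatter of it, while compound 1 lies clearly lower. Compound 4 `Cc1cc(C)cc(-c2nc(CN3CCC(C(=O)NCCCN4C[C@H](C)C[C@H](C)C4)CC3)c(C)o2)c1` differs from compound 3 in one place: 3,5-dimethylphenyl in place of 2-bromo-6-methoxyphenyl on an aromatic carbon. The step that bears most on this is a 3.7-fold higher number from compound 1 to compound 3 (0.56 log units; beyond the scatter), in which a 2,5-dimethylphenyl gave way to the 2-bromo-6-methoxyphenyl that now leaves; a 3.2-fold higher number from compound 1 to compound 2 (0.51 log units; beyond the scatter) points the same way for another ring, and a 1.1-fold higher number from compound 2 to compound 3 (0.05 log units; within the scatter) shows little between those two. A return to a dimethylphenyl is therefore expected roughly to reverse that step, so compound 4 is expected to show a 3.0-fold lower number from compound 3 to compound 4 (0.47 log units; beyond the scatter). Compound 4 is estimated at 5000 nM, within 2000 nM to 12000 nM.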

Compound 4, half-maximal cytotoxic concentration: 4050 nM
Beside the measured number, compound 4's estimate is 1.2-fold (0.09 log units) above it; the measured number falls inside the stated range.
By their numbers in this assay, from the lowest: compounds 4 and 1 (each within the scatter of the next); then compounds 2 and 3 (each within the scatter of the next).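

In this assay the 3,5-dimethylphenyl brings a 3.7-fold lower number from compound 3 to compound 4 (0.57 log units; beyond the scatter) and a 3.3-fold lower number from compound 2 to compound 4 (0.51 log units; beyond the scatter) and so repeats, with a second dimethylphenyl, the gap first seen with compound 1. Moving a methyl group around the ring gives a 1.0-fold lower number from compound 1 to compound 4 (0.00 log units; within the scatter) and so the two dimethylphenyl rings stand together at lower numbers than the 2,6-dichlorophenyl and 2-bromo-6-methoxyphenyl rings, with no compound shown going against this. No supporting data explain this gap. Still open, going by these compounds, is where a 2,6-dimethylphenyl or a 3,5-dichlorophenyl would fall, which would separate the kind of group from its place on the ring.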